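Pyrimidin-4-yl for pyridin-2-yl on the biaryl amide

This account rests on a few compounds, and the source may have more. Where it says the series, first, only, none or still open, it means among the compounds named here.

The series is read in an in vitro functional assay on HEK ts201 cells for antagonist activity at Neuronal acetylcholine receptor; alpha4/beta2 (Homo sapiens), read by fluorescence and calcium flux; a higher number here means a weaker inhibitor, a lower number a stronger inhibitor. Compound 1, `O=C(OCC1CCCN(CCCc2ccccc2)C1)c1ccc(-c2ccccc2)cc1`, gives 6310 nM. Compound 2, `CC1(C)CC(=O)N(c2ccccc2C(=O)OCC2CCCN(CCCc3ccccc3)C2)C1=O`, gives 4900 nM. Compound 3, `O=C(Nc1ccccn1)c1ccccc1-c1ccccc1`, gives 13600 nM, the highest number of the three; the gap to compound 1 and the gap to compound 2 both lie beyond the scatter, so compound 3 is the weakest inhibitor of the set shown. Among the measured compounds shown here, compounds 1 and 2 share a different core from compound 3, and no pair of measured compounds isolates a single change, so no reference step is available.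

Compound 4, `O=C(Nc1ccncn1)c1ccccc1-c1ccccc1`, is the next member. It differs from compound 3 as follows: pyrimidin-4-yl in place of pyridin-2-yl on an amide-type nitrogen. Ring size, attachment through the amide-type nitrogen and the rest of the molecule stay the same.

For the measured compounds named here, with no measured step of this kind to lean on, the expected change is a 1.0-fold lower number from compound 3 to compound 4 (0.02 log units; within the scatter), nothing beyond the scatter. The estimate for compound 4 in this assay is 13000 nM, with a range from 5500 nM to 32000 nM.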

Compound 4, half-maximal inhibitory concentration: 25100 nM
Beside the measured number, compound 4's estimate is 1.9-fold (0.29 log units) below it, and the stated range covers the measured number.
By their numbers in this assay, from the lowest: compounds 2 and 1 (each within the scatter of the next); then compounds 3 and 4 (each within the scatter of the next).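

Pyrimidin-4-yl in place of pyridin-2-yl on the amide-type nitrogen gives the only single-change step in the series so far in this assay (a 1.8-fold higher number from compound 3 to compound 4 (0.27 log units; within the scatter)). This step lies within the scatter, so at this place the two rings, with 1 and 2 hetero atoms, are not separated by this read-out, and a second ring nitrogen is accommodated without a readable difference. No measured evidence on either group bears on this result.

Going by these compounds, whether phenyl or pyridin-3-yl on the same amide-type nitrogen would read apart from compound 3 and compound 4 stays open, as does the effect of an amino or methoxy group on the pyrimidin-4-yl ring. Compound 1 and compound 2 differ from compound 3 in more than one place, so they say nothing about this change.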